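Piperidinyl urea series: permeability across the aryl group

A few compounds are considered here, and "the series" means these few. Any claim that something is new, unique, unknown or untested is made for them only; others in the source may bear on it.

Measured compounds in an ADME assay on MDCKII-LE cells (Canis lupus familiaris) for permeability, with a stated time of 1.5 h; on this read-out lower numbers stand for lower permeability and higher numbers for higher permeability:
- compound 1 `O=C(N1CCC(c2ccccc2)CC1)N(c1nccc2ccccc12)[C@@H]1CCCNC1`: 3.9 10^-6 cm/s
- compound 2 `O=C(c1ccc(-c2ccccc2)cc1)N(c1nccc2ccccc12)[C@@H]1CCCNC1`: 0.3 10^-6 cm/s
- compound 3 `Cc1ccc2c(N3CCN(C(=O)N(c4nccc5ccccc45)[C@@H]4CCCNC4)CC3)noc2c1`: 8.9 10^-6 cm/s

Compound 1 holds the second highest of the three numbers in this assay. Compound 3 sits nearest to it, with a higher number that lies beyond the scatter; compound 2 lies furthest away, with a far lower number, also beyond the scatter. For the measured compounds named here, no two of the measured compounds differ in only one place, so no single-point step is available to lean on.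

Compound 4 `Cc1nccnc1N(C(=O)N1CCC(c2ccccc2)CC1)[C@@H]1CCCNC1` is the next compound for this assay. Its difference from compound 1 is as follows: 3-methylpyrazin-2-yl in place of isoquinolin-1-yl on an amide-type nitrogen. Going by the values given here, no measured pair shows a change of this kind, so the expectation rests only on the values above. A modest downward step is expected from compound 1, of roughly the scatter or slightly beyond it, a 2.0-fold lower number from compound 1 to compound 4 (0.29 log units; within the scatter). Compound 4 is thus estimated at 2 10^-6 cm/s, with a range from 0.6 10^-6 cm/s to 6 10^-6 cm/s.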

Compound 4, apparent permeability: 11.5 10^-6 cm/s
For compound 4 the middle estimate is 5.8-fold (0.76 log units) below the measured one; the measured number lies above the stated range.
By their numbers in this assay, from the lowest: compound 2; then compound 1; then compounds 3 and 4 (each within the scatter of the next).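

In this assay, for the compounds shown here, the amide-type nitrogen of compound 1 gives the first single-place step: 3-methylpyrazin-2-yl in place of isoquinolin-1-yl brings a 2.9-fold higher number from compound 1 to compound 4 (0.47 log units; beyond the scatter). The entering group has fewer heavy atoms and more hydrogen-bond acceptors than the group it replaces, so at this position the read-out does not depend on keeping the two-ring isoquinolin-1-yl group. Nothing available accounts for the rise, so it stands as an observation only.

Still open, on these data alone, is whether the same exchange gives a similar step with the other carbonyl substituents, such as those of compound 2 and compound 3. The share of the methyl group in this step is also unresolved, as is the effect of an amine or a carboxylic acid on the aromatic ring at this nitrogen.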